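Trifluoromethylpyridinyl replacement at the oxadiazole position

The source may report more compounds than this note shows. Statements on the series, on what has been measured and on what is new or still open speak of the compounds shown alone.

The study so far holds two compounds. Compound 1 `C[C@H](NC(=O)c1cc(C(F)(F)F)nn1C)c1nc(-c2cccnc2)no1` gives 11800 nM in an assay on T-REx-293 cells for inhibition of potassium channel subfamily T member 1 (Homo sapiens), read by patch clamp; on this read-out higher numbers stand for weaker inhibition and lower numbers for stronger inhibition. For the measured compounds named here, compound 2 `COc1cc(-c2noc([C@H](C)NC(=O)c3cc(C(F)(F)F)nn3C)n2)cc(C)n1`, which carries 2-methoxy-6-methylpyridin-4-yl in place of pyridin-3-yl on an aromatic carbon, gives 505 nM in this assay, the lowest of the two numbers; the single measured step is a 23-fold lower number from compound 1 to compound 2 (1.37 log units; beyond the scatter). Compound 3 `C[C@H](NC(=O)c1cc(C(F)(F)F)nn1C)c1nc(-c2ccnc(C(F)(F)F)c2)no1` has not yet been measured. It differs from compound 2 by 2-(trifluoromethyl)pyridin-4-yl in place of 2-methoxy-6-methylpyridin-4-yl on an aromatic carbon. Going by the values given here, the only step that bears on this change is the one from compound 1 to compound 2, which altered the same aromatic carbon and was large. Since the group now entering lacks both the methoxy and the methyl of compound 2, one expects compound 3 to give a number higher than compound 2, with a 5.0-fold higher number from compound 2 to compound 3 (0.69 log units; beyond the scatter) in this assay. Compound 3 is therefore estimated at 2500 nM, within a range of 700 nM to 9000 nM.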

Compound 3, half-maximal inhibitory concentration: 40 nM
Compound 3: the middle estimate sits 63-fold (1.80 log units) above what was measured; measured number outside the range, below it.
By their numbers in this assay, from the lowest: compound 3; then compound 2; then compound 1.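

In this assay, the methoxy and the methyl of compound 2 prove unnecessary at this aromatic carbon, since 2-(trifluoromethyl)pyridin-4-yl, which carries neither, gives a 13-fold lower number from compound 2 to compound 3 (1.10 log units; beyond the scatter). Set against the pyridin-3-yl group, the same group gives a 300-fold lower number from compound 1 to compound 3 (2.47 log units; beyond the scatter), the widest gap among the compounds shown. With the pyridin-4-yl attachment held constant from compound 2 to compound 3, the change of substituents alone still moves the number well beyond the scatter, so this position responds strongly to what the pyridine ring carries, not only to how it is attached.

No measurement shown accounts for the better result with the trifluoromethyl group. On these data alone, a plain pyridin-4-yl group would separate the effect of the attachment from that of the trifluoromethyl group, and it remains open whether a chlorine atom or a nitrile could stand in its place.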